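A few compounds are considered here, and "the series" means these few. Any claim that something is new, unique, unknown or untested is made for them only; others in the source may bear on it.

Compound 1 `Cc1ccc2c(c1)c(-c1ccc[nH]c1=O)c(C(=O)O)n2Cc1cc([N+](=O)[O-])ccc1F`: 59 ng.h/mL
Compound 2 `O=C(NS(=O)(=O)C1CC1)c1c(-c2ccc[nH]c2=O)c2cc(Cl)ccc2n1Cc1cc([N+](=O)[O-])ccc1F`: 163 ng.h/mL

In an ADME assay on the whole organism (plasma) for pharmacokinetics, with Rattus norvegicus as the target, at a dose of 10 mg/kg by the oral route (on this read-out lower numbers stand for lower exposure and higher numbers for higher exposure at the dose given), compound 1 gives 59 ng.h/mL, the lowest of the two numbers; compound 2, which differs from it in several places, gives 163 ng.h/mL, a gap beyond the scatter. Compound 3 `Cc1ccc2c(c1)c(-c1ccc[nH]c1=O)c(C(=O)NS(C)(=O)=O)n2Cc1cc([N+](=O)[O-])ccc1F` is not yet measured. It carries methanesulfonamido in place of hydroxy on a carbonyl carbon. Among the measured compounds shown here, with no single-point step measured here, the direction rests only on the higher number of compound 2, which also carries a sulfonamide at that carbonyl, and the step of a 1.9-fold higher number from compound 1 to compound 3 (0.27 log units; within the scatter) is expected to be a modest rise. Compound 3 is therefore expected to give 110 ng.h/mL, somewhere between 40 ng.h/mL and 300 ng.h/mL.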

Compound 3, area under the concentration-time curve: 94.7 ng.h/mL
Estimate against measurement, compound 3: 1.2-fold (0.07 log units) above; the measured number falls inside the stated range.
By their numbers in this assay, from the lowest: compounds 1, 3 and 2 (each within the scatter of the next, the first and the last beyond it).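

In this assay, replacing the hydroxy on this carbonyl carbon with methanesulfonamido, with the rest of compound 1 unchanged, gives a step within the usual scatter (a 1.6-fold higher number from compound 1 to compound 3 (0.21 log units; within the scatter)). Among the compounds shown here, this is the first reading of this change on its own, and it does not put the two compounds in any order of exposure. Nothing measured here offers a reason for this result. Still open, going by these compounds, is how a plain amino group or an ethanesulfonamido group would read on the same carbonyl carbon.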